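This account rests on a few compounds, and the source may have more. Where it says the series, first, only, none or still open, it means among the compounds named here.

Compound 1 `Cc1cc(N2CCCC2)c2ncc(CSCCc3ccccc3)n2c1` reaches only the limit > 100 ug/mL in an ADME assay on HEL cells (Homo sapiens) for cytotoxicity, with a stated time of 3 days; a lower number here means that less compound is tolerated, a higher number that more compound is tolerated. Compound 2 `Cc1cc(C#N)c2ncc(CSCCc3ccccc3)n2c1` likewise reaches only the limit >= 20 ug/mL in this assay.

In this assay, within the data shown here, compound 2 therefore stands at a limit, and the one further value shown is a limit as well. The change to compound 3 `Cc1cc(Sc2ccc(Cl)cc2)c2ncc(CSCCc3ccccc3)n2c1` is (4-chlorophenyl)sulfanyl in place of cyano on an aromatic carbon. Among the measured compounds shown here, the only measured step, a step that the two limits leave unreadable from compound 1 to compound 2, cannot be sized, since both of its ends sit at limits, the limit of > 100 ug/mL in this assay, at which 1 of the 2 values shown sits, and (the limit of >= 20 ug/mL in this assay, at which 1 of the 2 values shown sits). For the measured compounds named here, no step of known size guides the expectation. From the compounds shown here alone, compound 3 is expected at 20 ug/mL, between 4 ug/mL and 100 ug/mL, an estimated step of a number no higher from compound 2 to compound 3 (the limit leaves the size open) whose direction remains open.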

Compound 3, minimum cytotoxic concentration: 4 ug/mL
For compound 3 the middle estimate is 5.0-fold (0.70 log units) above the measured one; measured number inside the range.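

Among these compounds, at this aromatic carbon, the (4-chlorophenyl)sulfanyl group gives the first steps of readable size in this assay, with an at least 5.0-fold lower number from compound 2 to compound 3 (0.69 log units; beyond the scatter) and an at least 25-fold lower number from compound 1 to compound 3 (1.39 log units; beyond the scatter). Compound 1 stands only at a limit, so the size of its step is a floor: the limit of > 100 ug/mL in this assay, at which 1 of the 3 values shown sits. Compound 2 also stands only at a limit, so the same holds for its step: the limit of >= 20 ug/mL in this assay, at which 1 of the 3 values shown sits.

The compounds shown do not separate the parts played by the sulfur, the ring and the chlorine. From the compounds shown here alone, how a phenoxy group at this carbon would stand in this assay also stays open.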